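The source may hold more compounds than are shown below. What is called first, only, known or untested is meant among the compounds shown, and "the series" means these compounds.

Measured so far in a functional assay on HL-60 cells (Homo sapiens) for inhibition; on this read-out higher numbers stand for weaker inhibition and lower numbers for stronger inhibition:
- compound 1 `OC[C@H]1OC(n2cnc3c(-c4cc[nH]c4)ncnc32)[C@H](O)[C@@H]1O`: 3200 nM
- compound 2 `OC[C@H]1OC(n2cnc3c(-c4ccc(O)cc4)ncnc32)[C@H](O)[C@@H]1O`: 7600 nM

Of these two, compound 2, at 7600 nM, has the higher number and so is the weaker inhibitor in this assay. The unmeasured compound 3 `OC[C@H]1OC(n2cnc3c(-c4cc[nH]n4)ncnc32)[C@H](O)[C@@H]1O` keeps the shared core and carries 1H-pyrazol-3-yl in place of 4-hydroxyphenyl on an aromatic carbon. Among the compounds with values here, only one measured step bears on this change: a 2.4-fold higher number from compound 1 to compound 2 (0.38 log units; beyond the scatter). In that modest step 4-hydroxyphenyl was the group entering, whereas here it leaves, and a single step is thin support. A modest move towards a lower number in this assay is therefore expected, of about the same size as that step. The expected change is a 2.2-fold lower number from compound 2 to compound 3 (0.34 log units; beyond the scatter). For compound 3 the estimated value is 3500 nM, with an expected range from 1100 nM to 12000 nM.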

Compound 3, half-maximal inhibitory concentration: 1170 nM
Compound 3: the middle estimate sits 3.0-fold (0.48 log units) above what was measured; the range from low to high includes it.
By their numbers in this assay, from the lowest: compound 3; then compound 1; then compound 2.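

In this assay, 1H-pyrazol-3-yl in place of 4-hydroxyphenyl gave a 6.5-fold lower number from compound 2 to compound 3 (0.81 log units; beyond the scatter) and was the largest step seen so far at this aromatic carbon. The two five-membered rings also separate from each other, with 1H-pyrazol-3-yl in place of 1H-pyrrol-3-yl giving a 2.7-fold lower number from compound 1 to compound 3 (0.44 log units; beyond the scatter), so the size of the ring alone does not set the number in this short series. No measurement at hand accounts for these differences.

The compounds shown leave open whether other five-membered rings with nitrogen, such as imidazolyl or 1,2,4-triazolyl, would carry the trend further. They also leave open whether an aromatic ring is needed here at all, or whether a simple amine or a short alkyl chain on this carbon would serve.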